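This account rests on a few compounds, and the source may have more. Where it says the series, first, only, none or still open, it means among the compounds named here.

Compound 1 `C/C=C(/C)C(=O)O[C@@H]1C=C(CO)C(=O)[C@@H](OC(=O)[C@]2(C)O[C@@H]2C)[C@@H]1C(C)C` was tested in an ADME assay on HEK293 cells (Homo sapiens) for cytotoxicity, read by XTT assay, with a stated time of 72 h (on this read-out lower numbers stand for stronger inhibition and higher numbers for weaker inhibition), and gave 3000 nM. Compound 2 `C/C=C(/C)C(=O)O[C@@H]1C(=O)C(CO)=C[C@@H](OC(=O)/C(C)=C/C)[C@H]1C(C)C` stands beside it; in this assay compound 2 gives 3000 nM, so the two values lie level at the digits shown and within the usual scatter of each other, and no order between them can be drawn. Among the measured compounds shown here, compound 1 thus sits at the same level as the only other measured compound, with no step between the two that goes beyond the scatter.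

Compound 3 `C/C=C(/C)C(=O)O[C@@H]1C=C(CO)C(=O)[C@@H](O)[C@@H]1C(C)C` has not yet been measured in this assay. It differs from compound 1 in one place: hydrogen in place of (2,3-dimethyloxiran-2-yl)carbonyl on an oxygen on a saturated carbon. Two stereocentres and one three-membered ring with a hetero atom go with the leaving group.

For the measured compounds named here, no measured pair shows what this change does, so the expectation rests on compound 1 alone, whose value of 3000 nM is the only anchor. A modest step toward weaker inhibition is expected, as a 3.3-fold higher number from compound 1 to compound 3 (0.52 log units; beyond the scatter). Compound 3 is therefore estimated at 10000 nM, with a range from 3000 nM to 40000 nM.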

Compound 3, half-maximal inhibitory concentration: 5500 nM
Compound 3: middle estimate off by 1.8-fold (0.26 log units), on the high side; the measured number falls inside the stated range.
By their numbers in this assay, from the lowest: compounds 1, 2 and 3 (each within the scatter of the next).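

Taking the (2,3-dimethyloxiran-2-yl)carbonyl off this oxygen on a saturated carbon, so that a hydroxy group stands in its place, gives in this assay a 1.8-fold higher number from compound 1 to compound 3 (0.26 log units; within the scatter) and so leaves the two compounds level within the usual scatter. Among the compounds shown here, for this one pair, then, the whole group, with its three-membered ring and its two defined stereocentres, is not required for a value at this level, something the earlier compounds could not show, as no step linked them. No measurement shown here speaks to why the read-out stays at this level with or without the group.

Going by these compounds, it remains open whether a longer acyl chain, or an acyl group carrying an amine or a carboxylic acid, on this same oxygen would also stay level with compound 1 or would move the number beyond the scatter. Also open, on these data alone, is whether a methyl ether in place of the free hydroxy of compound 3 would hold this level, and this single pair cannot say whether the result carries over to other changes on the shared core.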